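A few compounds are considered here, and "the series" means these few. Any claim that something is new, unique, unknown or untested is made for them only; others in the source may bear on it.

Values in a functional assay on U-251 cells (Homo sapiens) for inhibition, read by sulforhodamine B assay, with a stated time of 48 h (a lower number here means a stronger inhibitor of growth, a higher number a weaker inhibitor of growth), for the measured compounds:
compound 1 `O=C1C=COC(/C=C/c2ccccc2)C1` gives 122 uM
compound 2 `O=C1C=CCC(/C=C/c2ccccc2)N1` gives 798 uM
compound 3 `O=C1C=CCC(/C=C/c2ccccc2C(F)(F)F)N1` gives 69.9 uM

Compound 2 gives the highest number of the three; compound 1 stands nearest and compound 3 furthest, both beyond the scatter. Compound 4 `O=C1C=CCC(/C=C/c2ccc(C(F)(F)F)cc2)N1` has not yet been measured. It differs from compound 2 by trifluoromethyl in place of hydrogen on an aromatic carbon. Going by the values given here, the one measured step of the same kind of change is an 11-fold lower number from compound 2 to compound 3 (1.06 log units; beyond the scatter), a large step, though the place of the trifluoromethyl is not the same in compound 3 and compound 4. Among the compounds with values here, no second example of this change has been measured. On that basis a lower number than compound 2 is expected in this assay for compound 4, beyond the scatter, but not necessarily as large as the measured step. Compound 4 is expected to give about 150 uM, within 60 uM to 400 uM. That expected value amounts to a 5.3-fold lower number from compound 2 to compound 4 (0.73 log units; beyond the scatter).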

Compound 4, concentration for growth inhibition (reported as GI): 130 uM
Estimate against measurement, compound 4: 1.2-fold (0.06 log units) above; low and high end bracket the measured number.
By their numbers in this assay, from the lowest: compounds 3, 1 and 4 (each within the scatter of the next); then compound 2.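

In this assay, trifluoromethyl para to a group of 9 heavy atoms gives a 6.1-fold lower number from compound 2 to compound 4 (0.79 log units; beyond the scatter) and so provides a second example of this change, which had rested on compound 3 alone. The number falls from that of compound 2 at both places on the aromatic ring, with compound 3 at 69.9 uM and compound 4 at 130 uM in the same assay.

From the compounds shown here alone, whether a nitrile or a methoxy group at this place also lowers the number remains open, as does the effect of trifluoromethyl on the core of compound 1. Nothing available accounts for the size of the step.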